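The source may report more compounds than this note shows. Statements on the series, on what has been measured and on what is new or still open speak of the compounds shown alone.

Three compounds set the ground for this series. Compound 1 `CC(C)C(O)(c1cccc(-c2ccc(F)cc2)c1)c1c[nH]cn1` gives 19 nM in an assay on isolated protein for inhibition of steroid 17-alpha-hydroxylase/17,20 lyase (Homo sapiens); on this read-out higher numbers stand for weaker inhibition and lower numbers for stronger inhibition. Compound 2 `CC(C)C(O)(c1ccc(-c2ccc(Cl)cc2)cc1)c1c[nH]cn1` gives 28 nM in this assay. Compound 3 `CC(=O)Nc1cccc(-c2ccc(C(O)(c3c[nH]cn3)C(C)C)cc2)c1` gives 24 nM in this assay; that number is the second highest of the three, its nearest neighbour is compound 2 and its furthest is compound 1, and both of those gaps lie within the scatter, so the three numbers sit together and no order among them can be read.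

Compound 4 `CC(=O)Nc1cccc(-c2ccc([C@](O)(c3c[nH]cn3)C(C)C)cc2)c1` is the next case. (the two compounds have the same atoms and bonds; at least one stereo element is drawn with a configuration in one of them and without one in the other: 1 of 1 stereo elements differ; a stereocentre at a saturated chain carbon is drawn without a configuration in compound 3 and S in compound 4). Compound 3 is thus the material with that centre left undefined and compound 4 one configured form of the same pair. For the measured compounds named here, no step between two measured compounds carries this kind of difference, so nothing measured fixes the direction. If the two configurations are not equal in this assay, the configured form may give a somewhat lower or a clearly higher number than the undefined material; if they are, no step beyond the scatter would follow. Taking compound 3 at 24 nM as the anchor, the step from compound 3 to compound 4 is expected to be a 1.3-fold lower number from compound 3 to compound 4 (0.12 log units; within the scatter), with a broad margin. Compound 4 is estimated at 18 nM, within a range from 6 nM to 60 nM.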

Compound 4, half-maximal inhibitory concentration: 26 nM
Beside the measured number, compound 4's estimate is 1.4-fold (0.16 log units) below it; the measured number falls inside the stated range.
By their numbers in this assay, from the lowest: compounds 1, 3, 4 and 2 (each within the scatter of the next).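

For the compounds shown here, this is the first step between two compounds that differ in one place, and in this assay it reads a 1.1-fold higher number from compound 3 to compound 4 (0.03 log units; within the scatter). Within the scatter, then, the S form at this stereocentre at a saturated chain carbon cannot be told apart from the material with that centre left undefined, so the S form alone accounts for inhibition on the same level as that material, and drawing the centre as S opens no gap in this assay. The atoms and bonds stay the same throughout, so the step speaks only to the definition of this one centre and to no other part of the structure: the fact that one of compounds 3 and 4 is drawn with a defined configuration and the other without, at the place where they differ

Open, going by these compounds, is the number of the R form, and with it whether the two configurations differ at all in this assay, since the composition of the undefined material is not given and a match with the S form does not settle that question. Also open, on these data alone, is how the S form would read with a carboxylic acid or a longer chain in place of the acetamide of compound 4.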